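A few compounds are considered here, and "the series" means these few. Any claim that something is new, unique, unknown or untested is made for them only; others in the source may bear on it.

Compound 1, `CCOC(=O)c1ccc(Cl)cc1O[C@H]1CC[C@H]2CN[C@H](C(=O)OCC)C[C@H]2C1`, sets the reference point for this account. In a functional assay on the whole organism with Rattus norvegicus as the target (a lower number here means that less compound is needed, a higher number that more compound is needed for the effect), compound 1 gives only > 10 mg/kg, which is a limit of the assay and not a number. That reading places compound 1 at the limit of > 10 mg/kg in this assay, at which 1 of the 3 values shown sits. Two companions share the core with compound 1 but carry no chloro. Compound 2, `CCOC(=O)c1ccccc1S[C@H]1CC[C@H]2CN[C@H](C(=O)OCC)C[C@H]2C1`, gives 10 mg/kg in this assay. Compound 3, `CCOC(=O)c1ccc(C[C@H]2CC[C@H]3CN[C@H](C(=O)OCC)C[C@H]3C2)cc1`, gives 10 mg/kg in this assay, a value within the usual scatter of that of compound 2, so the two cannot be ranked against each other.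

The move from compound 1 to compound 4, `CCOC(=O)c1ccccc1O[C@H]1CC[C@H]2CN[C@H](C(=O)OCC)C[C@H]2C1`, is a single change: hydrogen in place of chloro on an aromatic carbon. Going by the values given here, no measured pair in the set differs by exactly this change, so no step can be computed for it. What the set does show is that compound 2 and compound 3, which both lack a chloro, each reach a numerical value, whereas compound 1 does not. On that basis compound 4 is expected to move in the direction of less compound needed, by a step of a number no higher from compound 1 to compound 4 (the limit leaves the size open), though the size is uncertain since compound 1 contributes only a limit. Compound 4 is therefore estimated at 10 mg/kg in this assay, within a range from 3 mg/kg to 30 mg/kg.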

Compound 4, minimum effective dose: 10 mg/kg
The estimate for compound 4 equals the measured number at the digits printed; the range from low to high includes it.
By their numbers in this assay, from the lowest: compounds 2, 3 and 4 (each within the scatter of the next).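

In this assay, going by these compounds alone, hydrogen in place of the chloro on the aromatic carbon para to an ethoxycarbonyl group gives a number no higher from compound 1 to compound 4 (the limit leaves the size open); this is the first pair in the set that differs at this position alone, as compound 2 and compound 3 each differ from compound 1 in more than one place. Compound 1 stands at > 10 mg/kg, which is a limit of the assay and not a number, so the size of this step cannot be read. Without the chloro, compound 4 gives 10 mg/kg and compound 2, which carries sulfur in place of the oxygen, gives 10 mg/kg, so these two values lie within the scatter of each other and that single exchange shows no difference here.

How far compound 1 lies from the other compounds stays open, with only this one compound resting on the limit: the limit of > 10 mg/kg in this assay, at which 1 of the 4 values shown sits. The compounds shown also leave open how other groups on this aromatic carbon, such as fluoro, methoxy or an amine, would read, and whether a chloro here would give a limit with sulfur in place of the oxygen.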